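A few compounds are considered here, and "the series" means these few. Any claim that something is new, unique, unknown or untested is made for them only; others in the source may bear on it.

Measured so far:
compound 1 `Cc1ccc(Oc2ccc(C#N)cc2S(=O)(=O)NC(=O)NC(C)(C)C)cc1` — 750 nM
compound 2 `CCCCCNC(=O)NS(=O)(=O)c1cc(C#N)ccc1Oc1ccc(C)cc1` — 900 nM

In a functional assay on HEK293 cells for antagonist activity at thromboxane A2 receptor (Homo sapiens), read by fluorescence and calcium flux (on this read-out lower numbers stand for stronger inhibition and higher numbers for weaker inhibition), compound 1 gives 750 nM, the lowest of the two numbers. Compound 2 gives 900 nM, and the step of a 1.2-fold higher number from compound 1 to compound 2 (0.08 log units; within the scatter) stays within the scatter. Compound 3 `CC(C)(C)NC(=O)NS(=O)(=O)c1cc(C#N)ccc1Oc1ccc(Cl)cc1` differs from compound 1 by chloro in place of methyl on an aromatic carbon. Among the compounds with values here, the only measured step changes the group on the amide-type nitrogen, not this ring, so it gives no guide to the size of this change. The expectation is therefore no step beyond the scatter, no change at the digits printed from compound 1 to compound 3 (within the scatter); compound 3 is estimated at 750 nM, in the range 300 nM to 1900 nM.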

Compound 3, half-maximal inhibitory concentration: 5640 nM
The estimate for compound 3 lay 7.5-fold (0.88 log units) below the measured number; measured number above the stated range.
By their numbers in this assay, from the lowest: compounds 1 and 2 (each within the scatter of the next); then compound 3.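

Changing 4-methylphenoxy to 4-chlorophenoxy gives a 7.5-fold higher number from compound 1 to compound 3 (0.88 log units; beyond the scatter) in this assay, so this para substituent matters on this read-out. Exchanging one heavy atom for one, with no hydrogen-bond donor or acceptor gained or lost, is enough to take the step beyond the scatter, and methyl gives the lower number of the two groups. No measurement here accounts for this step. Going by these compounds, what fluoro, methoxy or an amine would give at this position remains open, as does whether chloro would produce a similar step with pentyl on the amide-type nitrogen.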